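Naphthyl-pyridine series: acid to acrylamide swap

The source may hold more compounds than are shown below. What is called first, only, known or untested is meant among the compounds shown, and "the series" means these compounds.

Measured so far:
compound 1 `O=C(O)COc1ccncc1-c1ccc2ccccc2c1` — 16%
compound 2 `COC1CN(C(=O)/C=C/c2ccncc2-c2ccc(F)cc2)C1` — 77%
compound 3 `CN1CCN(C(=O)/C=C/c2ccncc2-c2ccc(F)cc2)CC1` — 84%

In an assay on a protein complex for inhibition of CDK8/Cyclin C (Homo sapiens), with a stated time of 1 h, tested at 10 uM (on this read-out higher numbers stand for more inhibition at the one concentration tested (going by the name of the read-out) and lower numbers for less inhibition), compound 1 gives 16%, the lowest of the three numbers. Compound 2 gives 77% and compound 3 gives 84%; both stand far above compound 1 and beyond the scatter, while a number 7 percentage points higher from compound 2 to compound 3 (within the scatter) shows that swapping the amine on the carbonyl does little within this pair.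

Compound 4 `NC(=O)/C=C/c1ccncc1-c1ccc2ccccc2c1` is compound 1 with the change (2-carbamoylethenyl in place of carboxymethoxy on an aromatic carbon). For the measured compounds named here, no measured step changes this position on the shared core alone: compounds 2 and 3 differ from compound 1 both in the chain at this position and in the aryl group, so their high values cannot be cleanly assigned to either change. Going by the values given here, still, the ethenyl-carbonyl chain is common to compounds 2 and 3 and absent from compound 1, and the only recorded step on that chain, a number 7 percentage points higher from compound 2 to compound 3 (within the scatter), is small.

On that basis a large rise is expected, a number 49 percentage points higher from compound 1 to compound 4 (beyond the scatter), with wide uncertainty since the amide here is primary rather than cyclic. Compound 4 is estimated at 65%, within 35% to 90% in this assay.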

Compound 4, a percentage reported as inhibition, at one concentration (the size of the read-out at that concentration, not a potency): 102%
Estimate against measurement, compound 4: 37 percentage points below; measured number above the stated range.
By their numbers in this assay, from the lowest: compound 1; then compounds 2 and 3 (each within the scatter of the next); then compound 4.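

With the core of compound 1 held fixed, 2-carbamoylethenyl in place of carboxymethoxy on the aromatic carbon opposite the ring nitrogen gives a number 86 percentage points higher from compound 1 to compound 4 (beyond the scatter) in this assay, so a change at this position alone is enough for a large step, something compounds 2 and 3 could not show, as they also differ from compound 1 in the aryl group. The two groups match in heavy atoms and hydrogen-bond donors, so the step goes with a change in the make-up of the chain, not in its heavy-atom count, and a primary amide on the ethenyl chain is enough for it, with no cyclic amine on the carbonyl. Nothing available gives a reason for the size of this step.

The compounds shown do not separate the double bond from the amide: a saturated 2-carbamoylethyl chain, a 2-carboxyethenyl chain carrying the carboxylic acid, and a carbamoylmethoxy chain would each change only one of the two. Also open is how the 4-methylpiperazine and 3-methoxyazetidine amides behave on the core of compound 4, and the single-concentration read-out gives no potency for any of these compounds.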